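The compounds below may be only part of what the source reports. "The series", "measured", "known", "first", "only" and "open" are said of these compounds alone.

Measured in a functional assay on MCF7 cells (Homo sapiens) for antiproliferative activity, read by MTT assay, with a stated time of 24 h; a lower number here means a stronger inhibitor, a higher number a weaker inhibitor:
- compound 1 `CCN(CC)CCNC(=O)c1ccc(C(CC)(CC)c2ccc(OCS(=O)(=O)c3ccccc3)c(C)c2)n1CC`: 4680 nM
- compound 2 `CCn1c(C(=O)N[C@H](CC(=O)O)C(=O)O)ccc1C(CC)(CC)c1ccc(OCS(=O)(=O)c2ccccc2)c(C)c1`: > 50000 nM

Not yet measured: compound 3 `CCn1c(C(=O)N[C@@H](CCC(=O)O)C(=O)O)ccc1C(CC)(CC)c1ccc(OCS(=O)(=O)c2ccccc2)c(C)c1`.

In this assay compound 2 reads > 50000 nM, which is a limit of the assay and not a number. Compound 3 carries 1,3-dicarboxypropyl in place of 1,2-dicarboxyethyl on an amide-type nitrogen. Among the measured compounds shown here, the only measured step is an at least 10-fold higher number from compound 1 to compound 2 (1.02 log units; beyond the scatter), large and beyond the scatter, and it brought in the 1,2-dicarboxyethyl group. Compound 3 keeps a dicarboxy chain, so no return towards compound 1 is expected. The expected change stays within the scatter, an estimated step that the limit leaves unreadable from compound 2 to compound 3. For compound 3 the estimate is 60000 nM, with an expected range of 25000 nM to 150000 nM.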

Compound 3, half-maximal inhibitory concentration: > 50000 nM
Compound 3 was reported as a limit; the forecaster's own chance of this, stated with the estimate: 70%; the middle value does not contradict the limit.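

In this assay, 1,3-dicarboxypropyl on the amide-type nitrogen gives an at least 10-fold higher number from compound 1 to compound 3 (1.02 log units; beyond the scatter), so the large step seen with 1,2-dicarboxyethyl is not confined to that one dicarboxy chain. Compound 3 reads > 50000 nM, which is a limit of the assay and not a number. The step between compound 2 and compound 3 cannot be read, and the two chains cannot be ranked: the limit of > 50000 nM in this assay, at which 2 of the 3 values shown sit.

Going by these compounds, how far either compound lies past this limit stays open. Also open, on these data alone, is where a chain with a single carboxylic acid, or a primary amine in place of the diethylamino group, would fall in this assay.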